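A few compounds are considered here, and "the series" means these few. Any claim that something is new, unique, unknown or untested is made for them only; others in the source may bear on it.

In an ADME assay on MT4 cells (Homo sapiens) for cytotoxicity, read by MTT assay, with a stated time of 96 h (a lower number here means that less compound is tolerated, a higher number that more compound is tolerated), compound 1 (`NS(=O)(=O)c1ccc(N2N=C(c3ccc(OCc4ccccc4)cc3)CC2c2ccccc2Cl)cc1`) gives 26000 nM and compound 2 (`NS(=O)(=O)c1ccc(N2N=C(c3ccc(Oc4ccccc4)cc3)CC2c2cccc(F)c2)cc1`) gives 25000 nM and the two numbers lie within the scatter of each other. Compound 3 (`NS(=O)(=O)c1ccc(N2N=C(c3ccc(OCc4ccccc4)cc3)CC2c2cccc(F)c2)cc1`) differs from compound 2 by one change (benzyl in place of phenyl on an oxygen on an aromatic ring) with benzyl in place of phenyl on an oxygen on an aromatic ring. For the measured compounds named here, no measured step covers this change. Compound 1 also carries benzyloxy and stands at 26000 nM so no shift beyond the scatter is expected in either direction. The expected step is small (no change at the digits printed from compound 2 to compound 3 (within the scatter)). Compound 3 is estimated at 25000 nM with an expected range from 11000 nM to 60000 nM as a working figure.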

Compound 3, half-maximal cytotoxic concentration: 65000 nM
Compound 3: the middle estimate sits 2.6-fold (0.41 log units) below what was measured, and the stated range ends below it.
By their numbers in this assay, from the lowest: compounds 2 and 1 (each within the scatter of the next); then compound 3.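

In this assay, for the compounds shown here, benzyl in place of phenyl on an oxygen on an aromatic ring gives a 2.6-fold higher number from compound 2 to compound 3 (0.41 log units; beyond the scatter) and is the first step to pass the scatter. With benzyloxy held, 3-fluorophenyl in place of 2-chlorophenyl on a saturated ring carbon gives a 2.5-fold higher number from compound 1 to compound 3 (0.40 log units; beyond the scatter) so benzyloxy alone does not set the number. Nothing at hand explains either step.

On these data alone, whether the phenoxy to benzyloxy step holds with 2-chlorophenyl on the saturated ring carbon stays open. So does the outcome with a longer chain, such as 2-phenylethyl, on the oxygen.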